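Oxime ester in place of trifluoromethyl oxime on the core

The source may hold more compounds than are shown below. What is called first, only, known or untested is meant among the compounds shown, and "the series" means these compounds.

Measured compounds:
compound 1 `OC1O[C@H](CO/N=C2\CCc3cc(Sc4cc(F)cc(C5CCOCC5)c4)ccc32)[C@H](O)[C@H](O)[C@H]1O` — > 2500 nM
compound 2 `CC(C)/C(=N\O)c1ccc(Sc2cc(F)cc(C3CCOCC3)c2)cc1` — 300 nM
compound 3 `O/N=C(/c1ccc(Sc2cc(F)cc(C3CCOCC3)c2)cc1)C(F)(F)F` — 280 nM

In a functional assay (blood) for inhibition, with Homo sapiens as the target (on this read-out lower numbers stand for stronger inhibition and higher numbers for weaker inhibition), compound 1 gives only a limit, > 2500 nM. Compound 2 gives 300 nM and compound 3 gives 280 nM; compound 3 thus has the lowest of the two numbers, with compound 2 nearest. Going by the values given here, the one measured step, a 1.1-fold lower number from compound 2 to compound 3 (0.03 log units; within the scatter), is the exchange of trifluoromethyl for isopropyl on the carbon with a double bond to nitrogen and stays within the scatter.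

Compound 4 `C/C(=N\OC(=O)C(C)(C)C)c1ccc(Sc2cc(F)cc(C3CCOCC3)c2)cc1` differs from compound 3 by a group of 10 heavy atoms (7 carbon, 1 nitrogen, 2 oxygen; no ring) in place of a group of 7 heavy atoms (2 carbon, 1 nitrogen, 1 oxygen, 3 fluorine; no ring), on an aromatic carbon. Among the compounds with values here, no measured step touches the oxygen of the oxime or an ester, so the measured step gives no direction here; compound 1 shows only that a large group on that oxygen reached the limit. Compound 4 is therefore expected to give roughly 700 nM, in the range 200 nM to 3000 nM, which would mean an estimated step of a 2.5-fold higher number from compound 3 to compound 4 (0.40 log units; beyond the scatter).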

Compound 4, half-maximal inhibitory concentration: 40 nM
Compound 4: middle estimate off by 18-fold (1.24 log units), on the high side, outside the stated range (below it).
By their numbers in this assay, from the lowest: compound 4; then compounds 3 and 2 (each within the scatter of the next). At a limit, above all of these: compound 1.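

Unlike the exchange of trifluoromethyl for isopropyl, which stayed within the scatter, replacing either whole group on this aromatic carbon, para to a large group, with the oxime ester moves the number in this assay beyond the scatter: the change gives a 7.0-fold lower number from compound 3 to compound 4 (0.85 log units; beyond the scatter) and a 7.5-fold lower number from compound 2 to compound 4 (0.88 log units; beyond the scatter). So this position can respond to a change, and the entering group, which has no hydrogen-bond donor, gives the lowest number of the series. Nothing shown here gives a reason for this difference.

The step changes both the group on the carbon of the oxime and the group on its oxygen, so the compounds shown do not separate the two. Going by these compounds, it remains open how a methyl oxime with a free hydroxyl, or an acetyl ester or carbamate on that oxygen, would compare.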